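A few compounds are considered here, and "the series" means these few. Any claim that something is new, unique, unknown or untested is made for them only; others in the source may bear on it.

For the measured compounds named here, in an ADME assay on MDCKII-LE cells (Canis lupus familiaris) for permeability (a higher number here means that the compound crosses the layer faster, a lower number that the compound crosses the layer more slowly), compound 3 `N#CCCCN([C@H](CCC(F)(F)F)C(N)=O)S(=O)(=O)c1ccc(Cl)cc1` gives 27.6 10^-6 cm/s and compound 1 `N#CC12CC(CN([C@H](CCC(F)(F)F)C(N)=O)S(=O)(=O)c3ccc(Cl)cc3)(C1)C2` gives 30.2 10^-6 cm/s, while compound 2 `N#CCCN([C@H](CCC(F)(F)F)C(N)=O)S(=O)(=O)c1ccc(Cl)cc1` gives 10.2 10^-6 cm/s, the only clearly lower number. Compound 4 `N#C[C@H]1C[C@@H]1CN([C@H](CCC(F)(F)F)C(N)=O)S(=O)(=O)c1ccc(Cl)cc1` brings (2-cyanocyclopropyl in place of 2-cyanoethyl on a saturated chain carbon bound to a sulfonamide nitrogen). Going by the values given here, three measured steps bear on this. The two steps involving the shortest chain were modest, a 2.7-fold higher number from compound 2 to compound 3 (0.43 log units; beyond the scatter) and a 3.0-fold lower number from compound 1 to compound 2 (0.47 log units; beyond the scatter), but compound 4 does not shorten the group. The closer precedent is the ring-bearing group of compound 1, where a 1.1-fold lower number from compound 1 to compound 3 (0.04 log units; within the scatter) shows that exchange for an open chain stayed within the scatter. No step beyond the scatter is therefore expected in this assay, and the estimated change is a 1.1-fold lower number from compound 3 to compound 4 (0.04 log units; within the scatter). For compound 4 the expected value is 25 10^-6 cm/s, with an estimated range of 13 10^-6 cm/s to 42 10^-6 cm/s.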

Compound 4, apparent permeability: 21.5 10^-6 cm/s
Compound 4: middle estimate off by 1.2-fold (0.07 log units), on the high side, and the stated range covers the measured number.
By their numbers in this assay, from the lowest: compound 2; then compounds 4, 3 and 1 (each within the scatter of the next).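

Closing the open chain into a ring did not move the number clearly in this assay: there is a 1.3-fold lower number from compound 3 to compound 4 (0.11 log units; within the scatter), and against the larger ring-bearing group there is a 1.4-fold lower number from compound 1 to compound 4 (0.15 log units; within the scatter). For the compounds shown here, the ring-bearing 2-cyanocyclopropyl therefore sits with those two groups, while a 2.1-fold higher number from compound 2 to compound 4 (0.32 log units; beyond the scatter) leaves compound 2 as the only clearly lower number of the four. No measurement shown gives a reason for these steps. The compounds shown leave open how this position would respond if a hydroxyl or an amine replaced the nitrile. They also do not show whether a longer chain would keep the number in this range.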